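Taking One Hydroxy Group Off Compound 2

The source may report more compounds than this note shows. Statements on the series, on what has been measured and on what is new or still open speak of the compounds shown alone.

Of the compounds shown here, two have been measured so far, and neither gives a true number. In a functional assay on KB-C2 cells (Homo sapiens) for cytotoxicity, read by MTT assay, with a stated time of 48 h (a higher number here means a weaker inhibitor, a lower number a stronger inhibitor), compound 1 (`C=C[C@@]1(C)COC(=O)[C@]12OC([C@H](C)CC)=CC2=O`) reads > 100 ug/mL as its result, which is a limit of the assay and not a number. Compound 2 (`C=C[C@@]1(C)COC(=O)C1(O)C(=O)/C=C(\O)c1ccccc1`) reads > 100 ug/mL as its result, which is again only a limit. Compound 2 therefore has no measured potency, and the record for both compounds is simply the limit of > 100 ug/mL in this assay, at which 2 of the 2 values shown sit, and nothing finer.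

Compound 3 (`C=C[C@@]1(C)COC(=O)C1C(=O)/C=C(\O)c1ccccc1`) is compound 2 with hydrogen in place of hydroxy on a saturated ring carbon. Going by the values given here, no measured pair shows what such a swap does in this assay so any forecast stays loose. The expectation rests on compound 2 at > 100 ug/mL as a limit, and it foresees no change beyond the scatter. The expected size of the move is a number no higher from compound 2 to compound 3 (the limit leaves the size open) with no firm direction. Compound 3 is estimated at 100 ug/mL as a central guess, with an expected range from 50 ug/mL to 200 ug/mL and a good chance of only a limit.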

Compound 3, half-maximal inhibitory concentration: 22.3 ug/mL
Estimate against measurement, compound 3: 4.5-fold (0.65 log units) above; measured number outside the range, below it.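

In this assay, putting hydrogen in place of hydroxy on this saturated ring carbon gives an at least 4.4-fold lower number from compound 2 to compound 3 (0.65 log units; beyond the scatter). Going by these compounds alone, this is the first pair of compounds differing in one place, and it shows that what sits on this ring carbon can shift the read-out: with hydrogen there, compound 3 gives a true number, while the hydroxy group of compound 2 goes with a result that is only a limit. The size of the step is therefore a floor and not an exact figure, and compound 3 is the only one of the three compounds with a real value, the rest of the record being a limit: the limit of > 100 ug/mL in this assay, at which 2 of the 3 values shown sit.

The compounds shown leave open whether the lower number comes from the loss of the hydroxy group or from the presence of hydrogen, and this single pair gives no reason for the change. A methoxy group, a fluorine atom or an amine on the same ring carbon would help to tell these readings apart and show how much this position tolerates.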